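The source may hold more compounds than are shown below. What is called first, only, known or untested is meant among the compounds shown, and "the series" means these compounds.

Measured so far, in an assay for inhibition of 6-phosphofructo-2-kinase/fructose-2,6-bisphosphatase 3 (Homo sapiens), read by ADP-Glo, with a stated time of 2 h; a lower number here means a stronger inhibitor, a higher number a weaker inhibitor:
compound 1 `CNC(=O)c1ccncc1Nc1cc(-c2ccc3ccn(C)c3c2)c2nccnc2c1` gives 83 nM;
compound 2 `CC(=O)N1CCOC(CNC(=O)c2ccncc2Nc2cc(-c3ccc4ccn(C)c4c3)c3nccnc3c2)C1` gives 93 nM.

Compound 2 has the higher of these two numbers, yet its gap to compound 1 is within the scatter. Compound 3 `CC(=O)N1CC(NC(=O)c2ccncc2Nc2cc(-c3ccc4ccn(C)c4c3)c3nccnc3c2)C1` differs from compound 2 by 1-acetylazetidin-3-yl in place of (4-acetylmorpholin-2-yl)methyl on an amide-type nitrogen. Going by the values given here, the only measured step that bears on this site is a 1.1-fold higher number from compound 1 to compound 2 (0.05 log units; within the scatter), which shows that changing what sits on this amide nitrogen did not move this assay beyond the scatter. A step within the scatter is therefore expected, a 1.1-fold higher number from compound 2 to compound 3 (0.03 log units; within the scatter). Compound 3 is estimated at 100 nM, between 45 nM and 250 nM.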

Compound 3, half-maximal inhibitory concentration: 73 nM
For compound 3 the middle estimate is 1.4-fold (0.14 log units) above the measured one, within the range that was stated.
By their numbers in this assay, from the lowest: compounds 3, 1 and 2 (each within the scatter of the next).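

In this assay, a third group on the amide-type nitrogen, 1-acetylazetidin-3-yl with its four-membered ring, also stays within the scatter of the other two (a 1.3-fold lower number from compound 2 to compound 3 (0.11 log units; within the scatter)) and (a 1.1-fold lower number from compound 1 to compound 3 (0.06 log units; within the scatter)). Methyl, (4-acetylmorpholin-2-yl)methyl and 1-acetylazetidin-3-yl therefore read alike at this position, so exchanging the six-membered ring for the four-membered one, or methyl for either ring, brings no change beyond the scatter. No supporting measurement accounts for this result. Going by these compounds, whether a free amine or a carboxylic acid on this nitrogen would read alike remains open.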